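A few compounds are considered here, and "the series" means these few. Any claim that something is new, unique, unknown or untested is made for them only; others in the source may bear on it.

Compound 1, `CC(C)CN1CCc2nc(C#Cc3ccccc3)sc2C1`: in an assay on HEK293 cells for positive allosteric modulation of metabotropic glutamate receptor 5 (Homo sapiens), read by FLIPR, with a stated time of 1 h (a lower number here means that less compound is needed, a higher number that more compound is needed for the effect), compound 1 gives > 10000 nM, which is a limit of the assay, not a number.
Compound 2, `O=C(C1CCC1)N1CCc2nc(C#Cc3ccccc3)sc2C1`: compound 2 gives > 10000 nM, again a limit.
Compound 3, `O=C(C1CCCC1)N1CCc2nc(C#Cc3ccccc3)sc2C1`: compound 3 gives 19 nM.

Among the measured compounds shown here, compound 3 therefore holds the only real number among the three, the other two values sitting at the limit of > 10000 nM in this assay, at which 2 of the 3 values shown sit. Compound 4, `CC(C)S(=O)(=O)N1CCc2nc(C#Cc3ccccc3)sc2C1`, differs from it by isopropylsulfonyl in place of cyclopentylcarbonyl on an amine nitrogen in a ring. Both measured steps reach compound 3 from a limit: an at least 520-fold lower number from compound 2 to compound 3 (2.72 log units; beyond the scatter) and an at least 520-fold lower number from compound 1 to compound 3 (2.72 log units; beyond the scatter), so exchanging the cyclopentylcarbonyl for either neighbour tested so far erased the effect. None of these steps involves a sulfonyl, so the new change is not directly covered. Still, a large rise is expected, a 160-fold higher number from compound 3 to compound 4 (2.20 log units; beyond the scatter), and compound 4 is estimated at 3000 nM, within 200 nM to 10000 nM.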

Compound 4, half-maximal effective concentration: > 10000 nM
Compound 4 gave a limit, no number (the forecaster's own chance of this, stated with the estimate: 50%); middle value at least 3.3-fold (0.52 log units) from the limit.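

The step to the sulfonyl, an at least 520-fold higher number from compound 3 to compound 4 (2.72 log units; beyond the scatter), shows that the effect is also lost at this amine nitrogen when a sulfonyl group replaces the carbonyl, not only with isobutyl or cyclobutylcarbonyl. The steps from compound 1 and compound 2 to compound 4 join two limits and cannot be read. Of the four groups on this nitrogen, only cyclopentylcarbonyl gives a real number, and the other three stop at one limit: the limit of > 10000 nM in this assay, at which 3 of the 4 values shown sit.

This change swaps the carbonyl for a sulfonyl and removes the ring together, so the two changes stay unseparated. On these data alone, a cyclopentylsulfonyl group would separate them, and whether a cyclohexylcarbonyl group keeps the effect remains open.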